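Replacing a Piperidine Amine Substituent with a Pyridylmethyl Arm

The source may report more compounds than this note shows. Statements on the series, on what has been measured and on what is new or still open speak of the compounds shown alone.

The series shares one core, seen in compound 1 `Cc1csc2cc([C@H](C)Nc3ncnc(N)c3C#N)c(-c3cccc(CN4CCC(N(C)CC(C)C)CC4)c3)c(=O)n12`. In a physicochemical assay for lipophilicity (on this read-out higher numbers stand for higher lipophilicity and lower numbers for lower lipophilicity), compound 1 gives 1.7, the second highest of the three numbers measured. Compound 2 `Cc1csc2cc([C@H](C)Nc3ncnc(N)c3C#N)c(-c3cccc(CC4CCN(C(C)C)CC4)c3)c(=O)n12` gives 1.1, and compound 3 `Cc1csc2cc([C@H](C)Nc3ncnc(N)c3C#N)c(-c3cccc(CN(C)CCCN(C)Cc4ccc(Cl)cc4)c3)c(=O)n12` gives 3.2, the highest of the three. Among the measured compounds shown here, the one step measured in a single place, a number 0.60 log units lower from compound 1 to compound 2 (beyond the scatter), shows that exchanging the amine-bearing piperidine for a simpler one lowers this assay modestly. Compound 4 `Cc1csc2cc([C@H](C)Nc3ncnc(N)c3C#N)c(-c3cccc(CN4CCC(CN(C)Cc5ccccn5)CC4)c3)c(=O)n12` differs from compound 1 by (methyl((pyridin-2-yl)methyl)amino)methyl in place of isobutyl(methyl)amino on a saturated ring carbon. For the measured compounds named here, no measured step follows this exact change; compound 3, which carries a benzyl group on a chain amine, sits well above compound 1, whereas the step from compound 1 to compound 2 shows that a trimmed basic group moves this assay down. Compound 4 is therefore expected to rise somewhat, by a number 0.30 log units higher from compound 1 to compound 4 (within the scatter), a step near the edge of the scatter. Compound 4 is estimated at 2, within 1.3 to 2.7.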

Compound 4, distribution coefficient: 2
Estimate against measurement, compound 4: no gap at the digits printed; low and high end bracket the measured number.
By their numbers in this assay, from the lowest: compound 2; then compounds 1 and 4 (each within the scatter of the next); then compound 3.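

At the saturated ring carbon, (methyl((pyridin-2-yl)methyl)amino)methyl in place of isobutyl(methyl)amino gives, in this assay, a number 0.30 log units higher from compound 1 to compound 4 (within the scatter), so this read-out does not separate the two compounds. The exchange goes from 6 to 10 heavy atoms and adds a six-membered aromatic ring with 1 hetero atom, so this position takes that larger group without a step beyond the scatter, unlike a number 0.60 log units lower from compound 1 to compound 2 (beyond the scatter), where the whole piperidine substituent changes. Nothing available accounts for this result.

The compounds shown leave open whether the ring nitrogen of the pyridin-2-yl group matters here, which a phenyl ring on the same arm would test. They also leave open how a carboxylic acid or a longer chain at this ring carbon would read in this assay.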